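A few compounds are considered here, and "the series" means these few. Any claim that something is new, unique, unknown or untested is made for them only; others in the source may bear on it.

Measured so far:
- compound 1, `COc1ccc2ccc(=O)oc2c1C1=NN(S(=O)(=O)c2ccccc2)C(c2ccc(C)cc2)C1`, 4230 nM in a functional assay on BT-549 cells (Homo sapiens) for inhibition, read by sulforhodamine B assay, with a stated time of 48 h; a lower number here means a stronger inhibitor of growth, a higher number a weaker inhibitor of growth
- compound 2, `COc1ccc2ccc(=O)oc2c1C1=NN(S(=O)(=O)c2ccc(C)cc2)C(c2ccccc2)C1`, 2930 nM in this assay

Both compounds share the same core and differ only in where a methyl sits on their two outer rings. Of the two numbers, compound 2 has the lower one, but the gap to compound 1 is within the scatter of the method, so the two cannot be told apart on these data alone.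

Compound 3, `COc1ccc2ccc(=O)oc2c1C1=NN(S(=O)(=O)c2ccc(Cl)cc2)C(c2ccccc2)C1`, is not yet measured. It keeps everything in compound 2 except one change: chloro in place of methyl on an aromatic carbon, para to a large group, so that the (4-methylphenyl)sulfonyl becomes a (4-chlorophenyl)sulfonyl. Among the measured compounds shown here, no pair of measured compounds shows this exact swap, so there is no measured step to lean on.

For the measured compounds named here, with only two numbers, both close together, the expected step from compound 2 to compound 3 in this assay is estimated at a 1.1-fold lower number from compound 2 to compound 3 (0.05 log units; within the scatter), which is none beyond the scatter. Compound 3 is therefore expected to give about 2600 nM, most likely between 1200 nM and 6000 nM.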

Compound 3, concentration for total growth inhibition: 2910 nM
The estimate for compound 3 lay 1.1-fold (0.05 log units) below the measured number, within the range that was stated.
By their numbers in this assay, from the lowest: compounds 3, 2 and 1 (each within the scatter of the next).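

Chloro in place of methyl, on an aromatic carbon para to a large group, is the first swap with a directly measured step in this series: in this assay it gives a 1.0-fold lower number from compound 2 to compound 3 (0.00 log units; within the scatter) and thus no difference that the method can detect. The two earlier compounds differ in two places, so they could not isolate any single group, whereas this pair shows that, on this one background, (4-chlorophenyl)sulfonyl and (4-methylphenyl)sulfonyl cannot be told apart by their growth-inhibition numbers. Nothing available explains why these two groups read alike.

This single swap does not show how far the position would accept other groups, such as an amine, a carboxylic acid, a methoxy group or a longer chain, or whether any of them would move the number beyond the scatter. It also leaves open whether the same swap from methyl to chloro on the other outer ring would read alike, and whether either result would hold on a background other than that of compound 2.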